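The compounds below may be only part of what the source reports. "The series", "measured", "known", "first", "only" and "open" are said of these compounds alone.

Measured in a functional assay on NIH3T3 cells (Mus musculus) for inhibition, read by MTT assay, with a stated time of 72 h; on this read-out higher numbers stand for weaker inhibition and lower numbers for stronger inhibition:
- compound 1 `C=C1CC[C@H]2[C@@](C)(CC[C@@H](OC(C)=O)[C@@]2(C)C(=O)OCc2ccccc2)[C@@H]1CCC1=CCOC1=O`: 12900 nM
- compound 2 `C=C1CC[C@H]2[C@@](C)(CC[C@@H](OC(C)=O)[C@@]2(C)C(=O)OCc2ccccn2)[C@@H]1CCC1=CCOC1=O`: 55500 nM
- compound 3 `C=C1CC[C@H]2[C@@](C)(CC[C@@H](O)[C@@]2(C)C(=O)OCc2ccccn2)[C@@H]1CCC1=CCOC1=O`: 79800 nM

Compound 2 sits close to compound 3, with a 1.4-fold higher number from compound 2 to compound 3 (0.16 log units; within the scatter). Compound 1 stands clearly apart from it, with a 4.3-fold higher number from compound 1 to compound 2 (0.63 log units; beyond the scatter). Compound 4 `C=C1CC[C@H]2[C@@](C)(CC[C@@H](OC(C)=O)[C@@]2(C)C(=O)OCc2ccccn2)[C@@H]1/C=C/C1=CCOC1=O` has not yet been measured in this assay. It differs from compound 2 as follows: a group of 8 heavy atoms (6 carbon, 2 oxygen; one five-membered non-aromatic ring with 1 hetero atom) in place of a group of 8 heavy atoms (6 carbon, 2 oxygen; one five-membered non-aromatic ring with 1 hetero atom), on a saturated ring carbon. The group that changes thus carries 3 double bonds outside aromatic rings instead of 2.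

Neither measured step touches this place. One exchanges phenyl for pyridin-2-yl, the other puts hydrogen in place of acetyl, so they show only how far this small series has moved on other changes. Going by the values given here, the data hold no direct precedent, and no step beyond the scatter is expected in either direction, though the uncertainty is wide. The estimate means a 1.1-fold lower number from compound 2 to compound 4 (0.05 log units; within the scatter), which is an expected step and not a measured one. For compound 4 the expected value is 50000 nM, with an estimated range of 18000 nM to 120000 nM.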

Compound 4, half-maximal inhibitory concentration: 34900 nM
Compound 4: the middle estimate sits 1.4-fold (0.16 log units) above what was measured, within the range that was stated.
By their numbers in this assay, from the lowest: compound 1; then compounds 4, 2 and 3 (each within the scatter of the next, the first and the last beyond it).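

Going by these compounds alone, compound 4 gives the only reading at this place on a saturated ring carbon: in this assay, the group with 3 double bonds outside aromatic rings in place of the group with 2 gives a 1.6-fold lower number from compound 2 to compound 4 (0.20 log units; within the scatter). On this pair, therefore, the two groups cannot be told apart on this read-out, although both carry the same five-membered non-aromatic ring and the same count of heavy atoms. Nothing available explains this result or bears on it further.

The compounds shown leave open whether the same exchange would read alike with phenyl in place of pyridin-2-yl, as in compound 1, or with hydrogen in place of acetyl, as in compound 3. They also leave open how this assay would respond at this place to a longer chain or to an amine on the chain.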